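One Carbonyl Substituent Separates Compound 3 from Compound 4

The source may hold more compounds than are shown below. What is called first, only, known or untested is meant among the compounds shown, and "the series" means these compounds.

In an ADME assay on L02 cells (Homo sapiens) for antiproliferative activity, read by MTT assay, with a stated time of 48 h (a higher number here means a weaker inhibitor, a lower number a stronger inhibitor), compound 1 (`CCn1c(C(=O)NCC#N)ccc1C(CC)(CC)c1ccc(OCCC(O)(CC)CC)c(C)c1`) gives > 50000 nM, which is a limit of the assay. Compound 2 (`C#CCCOC(=O)c1ccc(C(CC)(CC)c2ccc(OCCC(O)(CC)CC)c(C)c2)n1CC`) gives > 50000 nM, also a limit. Compound 3 (`CCOC(=O)CN(C)C(=O)c1ccc(C(CC)(CC)c2ccc(OCCC(O)(CC)CC)c(C)c2)n1CC`) alone returns a number, 1990 nM, and is the strongest of the three, as shown by an at least 25-fold lower number from compound 1 to compound 3 (1.40 log units; beyond the scatter) and by an at least 25-fold lower number from compound 2 to compound 3 (1.40 log units; beyond the scatter).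

Compound 4 (`CCn1c(C(=O)NC(C)C(=O)O)ccc1C(CC)(CC)c1ccc(OCCC(O)(CC)CC)c(C)c1`) differs from compound 3 as follows: (1-carboxyethyl)amino in place of ((ethoxycarbonyl)methyl)(methyl)amino on a carbonyl carbon. It thus loses the ((ethoxycarbonyl)methyl)(methyl)amino whose presence in compound 3 accompanies an at least 25-fold lower number from compound 1 to compound 3 (1.40 log units; beyond the scatter), so a large move back towards weaker inhibition is expected in this assay. The expected change is a 15-fold higher number from compound 3 to compound 4 (1.18 log units; beyond the scatter). For compound 4 the estimated value is 30000 nM, within an expected range of 5000 nM to 100000 nM.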

Compound 4, half-maximal inhibitory concentration: 4040 nM
The estimate for compound 4 lay 7.4-fold (0.87 log units) above the measured number; the whole stated range lies above it.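

The step of a 2.0-fold higher number from compound 3 to compound 4 (0.31 log units; beyond the scatter) in this assay is modest, so the position tolerates more than the ((ethoxycarbonyl)methyl)(methyl)amino of compound 3. With (1-carboxyethyl)amino on the same carbonyl carbon, a large step remains in an at least 12-fold lower number from compound 2 to compound 4 (1.09 log units; beyond the scatter) and in an at least 12-fold lower number from compound 1 to compound 4 (1.09 log units; beyond the scatter). The second of these swaps only cyanomethyl for 1-carboxyethyl on the amide-type nitrogen, so a low number here does not require a methyl on that nitrogen.

From the compounds shown here alone, the true size of both large steps stays open, since each starts from a limit: the limit of > 50000 nM in this assay, at which 2 of the 4 values shown sit. How an amine or a longer chain on this carbonyl carbon would read also stays open.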